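The compounds below may be only part of what the source reports. "The series", "measured", "known", "first", "only" and "open" are said of these compounds alone.

Measured in a functional assay on ileum (Cavia porcellus) for antagonist activity; a higher number here means a weaker inhibitor, a lower number a stronger inhibitor:
- Compound 1 `CC(=O)c1ccc(OCCCOc2ccc3c(O)c([N+](=O)[O-])c(=O)oc3c2)cc1O`: 2800 nM
- Compound 2 `CCCc1c(OCCCOc2ccc3c(O)c([N+](=O)[O-])c(=O)oc3c2)ccc(C(C)=O)c1O`: 100 nM

Of these two, compound 2 has the lower number, at 100 nM, and is the stronger inhibitor in this assay. Going by the values given here, only one measured step is available, a 28-fold lower number from compound 1 to compound 2 (1.45 log units; beyond the scatter). This large step came from propyl in place of hydrogen on an aromatic carbon.

The next compound, compound 3 `CCCc1c(OCC(O)COc2ccc3c(O)c([N+](=O)[O-])c(=O)oc3c2)ccc(C(C)=O)c1O`, keeps that propyl group and differs from compound 2 at a single place in the chain: hydroxy in place of hydrogen on a saturated chain carbon bound to two saturated chain carbons. That is, it has hydroxy in place of hydrogen on a saturated chain carbon bound to two saturated chain carbons.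

The step of a 28-fold lower number from compound 1 to compound 2 (1.45 log units; beyond the scatter) lies elsewhere in the molecule, so it says little about this change. Among the compounds with values here, no measured pair tests the hydroxy group, and the data give no direction for it. No step beyond the scatter is therefore expected, though the uncertainty is wide. The expected step is a 1.2-fold higher number from compound 2 to compound 3 (0.08 log units; within the scatter). For compound 3, the estimated value is 120 nM, with an expected range of 35 nM to 400 nM.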

Compound 3, half-maximal inhibitory concentration: 80 nM
For compound 3 the middle estimate is 1.5-fold (0.18 log units) above the measured one; measured number inside the range.
By their numbers in this assay, from the lowest: compounds 3 and 2 (each within the scatter of the next); then compound 1.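

In this assay, hydroxy in place of hydrogen on a saturated chain carbon bound to two saturated chain carbons gives a 1.3-fold lower number from compound 2 to compound 3 (0.10 log units; within the scatter) and so leaves the number within the scatter. Going by these compounds alone, this is the first measured test of that place in the chain, and it shows that, with the propyl group present, the place accepts a hydroxy group without a step beyond the scatter. Among the shown compounds, only the propyl change, with a 28-fold lower number from compound 1 to compound 2 (1.45 log units; beyond the scatter), moves the number beyond the scatter, and no measured evidence bears on why the hydroxy change does not.

Whether a hydroxy group on this chain carbon would give a similar result without the propyl group remains open, as the shown compounds offer no such comparison. Also open, as far as these compounds go, is what a methoxy group, an amine or a carboxylic acid on the same saturated chain carbon would do in this assay, and whether a longer chain in place of this one would keep the number within the scatter of compound 2 and compound 3.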